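This account rests on a few compounds, and the source may have more. Where it says the series, first, only, none or still open, it means among the compounds named here.

Measured so far in a functional assay on HeLa cells (Homo sapiens) for antiproliferative activity, read by MTT assay, with a stated time of 72 h; on this read-out lower numbers stand for stronger inhibition and higher numbers for weaker inhibition:
- compound 1 `O=C(Nc1ccc(Cl)c(-c2nnc3c(Cl)cccn23)c1)c1ccc(C(F)(F)F)cc1F`: 61900 nM
- compound 2 `CS(=O)(=O)c1ccc(C(=O)Nc2ccc(Cl)c(-c3nnc4c(Cl)cccn34)c2)cc1`: > 100000 nM (a limit of the assay, not a number)
- compound 3 `CS(=O)(=O)c1ccc(C(=O)Nc2ccc(Cl)c(-c3nnc4c(Cl)cccn34)c2)c(Cl)c1`: > 100000 nM (a limit of the assay, not a number)

Compound 2 stands only at a limit in this assay. Compound 3 sits at the same limit. The step that the two limits leave unreadable from compound 2 to compound 3 therefore cannot be read. Only compound 1, with a different acyl group, gives a number at all, and it is a weak one. The common thread is the limit of > 100000 nM in this assay, at which 2 of the 3 values shown sit.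

Compound 4 `CS(=O)(=O)c1cccc(C(=O)Nc2ccc(Cl)c(-c3nnc4c(Cl)cccn34)c2)c1` carries the change (3-(methylsulfonyl)phenyl in place of 4-(methylsulfonyl)phenyl on a carbonyl carbon). Going by the values given here, no measured step bears directly on this rearrangement; the one single-point step in the set, from compound 2 to compound 3, is hidden by the two limits. So no direction and no size beyond the scatter can be grounded for this change; the only anchor is that compound 2 and compound 3 both fail to show a number, and compound 1 barely does.

The estimate for compound 4 is 100000 nM, range 30000 nM to 300000 nM, meaning an expected step of a number no higher from compound 2 to compound 4 (the limit leaves the size open) from compound 2, with a high chance that this assay again reports only a limit.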

Compound 4, half-maximal inhibitory concentration: 86400 nM
Beside the measured number, compound 4's estimate is 1.2-fold (0.06 log units) above it; low and high end bracket the measured number.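

In this assay, going by these compounds alone, compound 4 gives a true number, 86400 nM, so 3-(methylsulfonyl)phenyl on the carbonyl carbon is the first methylsulfonyl-bearing group to yield a readable value. Compound 2, with 4-(methylsulfonyl)phenyl, gives > 100000 nM, which is a limit of the assay and not a number. The change can be stated only as an at least 1.1-fold lower number from compound 2 to compound 4 (0.06 log units; that floor lies within the scatter), so no gain beyond the scatter can be claimed for it, and activity in this series remains weak.

On these data alone, the true size of this step stays open, and the step from compound 2 to compound 3 cannot be read, with one obstacle behind both: the limit of > 100000 nM in this assay, at which 2 of the 4 values shown sit. Also open, as far as these compounds go, is how the number of compound 4 would respond to a carboxylic acid or an amine in place of its methylsulfonyl group.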